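The source may report more compounds than this note shows. Statements on the series, on what has been measured and on what is new or still open speak of the compounds shown alone.

Two compounds of the series have numbers. Compound 1 `Cc1c(COc2cc(N)nc3[nH]nnc23)cccc1-c1ccn(C)n1` in an assay for inhibition of Myeloperoxidase (Homo sapiens), read by Amplex Red, with stated times of 10 min and 15 min (a higher number here means a weaker inhibitor, a lower number a stronger inhibitor), gives 26 nM. Compound 2 `Cc1nn(-c2ccccc2)nc1COc1cc(N)nc2[nH]nnc12` in this assay gives 27 nM, the higher of the two numbers, although its gap to compound 1 lies within the scatter, so the two are read as equivalent. Going by the values given here, no pair of measured compounds differs in a single place, so no measured step is available to calibrate a change of the kind below.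

Compound 3 `Nc1cc(OCc2nn(-c3ccccc3)nc2C(F)F)c2nn[nH]c2n1` has not yet been measured in this assay. It differs from compound 2 by difluoromethyl in place of methyl on an aromatic carbon. With no measured step of this kind in hand, the size of the change is taken from the two numbers alone, and no movement beyond the scatter is expected, in either direction. Compound 3 is expected to give 30 nM in this assay, with a range from 12 nM to 80 nM. This estimate means a step of a 1.1-fold higher number from compound 2 to compound 3 (0.05 log units; within the scatter), which is expected to stay within the scatter.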

Compound 3, half-maximal inhibitory concentration: 12 nM
Beside the measured number, compound 3's estimate is 2.5-fold (0.40 log units) above it; low and high end bracket the measured number.
By their numbers in this assay, from the lowest: compound 3; then compounds 1 and 2 (each within the scatter of the next).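

Difluoromethyl in place of methyl on this aromatic carbon gives a 2.3-fold lower number from compound 2 to compound 3 (0.35 log units; beyond the scatter) in this assay and is the first single-place step of the series. The position is therefore not silent: a change here moves the number beyond the scatter, and the enlarged group, on the carbon next to the ring atom that bears a large group, comes with no loss of inhibition. Nothing measured on these compounds accounts for the lower number.

Only one replacement has been read at this carbon, so the step cannot yet be tied to the fluorine atoms rather than to the larger group; trifluoromethyl, fluoromethyl or ethyl in the same place would separate the two. Going by these compounds, whether the same replacement on the methyl of compound 1 gives a step of similar size also remains open.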